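Adding a Methylpiperazine to a Pyrazolopyridinone Pair

The compounds below may be only part of what the source reports. "The series", "measured", "known", "first", "only" and "open" are said of these compounds alone.

Measured so far:
Compound 1 `Cn1nc(N)c2c(=O)[nH]c(-c3ccccc3)cc21` gives 9% in an assay on isolated protein for inhibition of ribosomal protein S6 kinase alpha-5 (Homo sapiens), read by mobility shift assay, tested at 30 uM; a lower number here means less inhibition, a higher number more inhibition at the concentration tested (going by the name of the read-out).
Compound 2 `CC(=O)Nc1nn(C)c2cc(-c3ccccc3)[nH]c(=O)c12` gives 3% in this assay.

Compound 2 stands beside compound 1 on these numbers: the step of a number 6 percentage points lower from compound 1 to compound 2 (within the scatter) does not separate them, and both read as little inhibition. That step, acetyl in place of hydrogen on a nitrogen on an aromatic ring, is the only measured one.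

Compound 3 `CC(=O)Nc1nn(C)c2cc(-c3ccc(N4CCN(C)CC4)cc3)[nH]c(=O)c12` differs from compound 2 by 4-methylpiperazin-1-yl in place of hydrogen on an aromatic carbon. For the measured compounds named here, the group enters on the six-membered aromatic ring of carbon only, para to a large group, a site that no measured step touches. Going by the values given here, the one step on record alters a different part of the shared core and lies within the scatter, so it gives no guide to this change. Nothing here points to a step beyond the scatter in this assay in either direction. The expected step is a number 3 percentage points higher from compound 2 to compound 3 (within the scatter). Compound 3 is therefore estimated at 6%, between -5% and 22%.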

Compound 3, a percentage reported as inhibition, at one concentration (the size of the read-out at that concentration, not a potency): 0%
The estimate for compound 3 lay 6 percentage points above the measured number; the range from low to high includes it.
By their numbers in this assay, from the lowest: compounds 3, 2 and 1 (each within the scatter of the next).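

For the compounds shown here, compound 3 gives the first measured change on the six-membered aromatic ring of carbon only, and in this assay the step (a number 3 percentage points lower from compound 2 to compound 3 (within the scatter)) does not separate it from compound 2. Placing 4-methylpiperazin-1-yl on this aromatic carbon, para to a large group, therefore brings no inhibition beyond the scatter, and all three compounds read as little inhibition at the concentration tested. No available measurement offers an explanation for this result.

From the compounds shown here alone, whether a carboxylic acid, a morpholine or a longer amine chain on the same aromatic carbon would produce a step beyond the scatter remains open. Going by these compounds, it is also open whether 4-methylpiperazin-1-yl would behave in the same way on the core of compound 1, which has hydrogen in place of the acetyl.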